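The source may hold more compounds than are shown below. What is called first, only, known or untested is meant among the compounds shown, and "the series" means these compounds.

Working notes on the series. For the measured compounds named here, compound 1 `CC(=O)OC/C1=C/C[C@](C)(CCC=C(C)C)/C=C/[C@@H](OC(=O)C=C(C)C)[C@](C)(O)/C=C/C1=O` gives the lowest of the three numbers so far in a functional assay on MCF7 cells (Homo sapiens) for antiproliferative activity, read by MTT assay, with a stated time of 48 h (a lower number here means a stronger inhibitor, a higher number a weaker inhibitor), at 4510 nM. Compound 2 `CC(C)=CCC[C@]1(C)/C=C/[C@@H](OC(=O)C=C(C)C)[C@](C)(O)/C=C/C(=O)/C(C[Si](C)(C)C(C)(C)C)=C\C1` gives 6040 nM, and compound 3 `CC(C)=CCC[C@]1(C)/C=C/[C@@H](OC(=O)C=C(C)C)[C@](C)(O)/C=C/C(=O)/C(C[Si](c2ccccc2)(c2ccccc2)C(C)(C)C)=C\C1` gives 15800 nM. Going by the values given here, the only single-point step measured is a 1.3-fold higher number from compound 1 to compound 2 (0.13 log units; within the scatter). Compound 4 `CC(C)=CCC[C@]1(C)/C=C/[C@@H](OC(=O)C=C(C)C)[C@](C)(O)/C=C/C(=O)/C(COC(=O)c2ccc([N+](=O)[O-])cc2)=C\C1` differs from compound 1 by 4-nitrophenyl in place of methyl on a carbonyl carbon. Among the compounds with values here, no measured pair changes the group on the carbonyl carbon itself; the nearest comparison is the step from compound 1 to compound 2, which replaced the whole acetoxy group and stayed within the scatter, while compound 3 with the larger silicon group sits further up. A step of a 1.6-fold higher number from compound 1 to compound 4 (0.19 log units; within the scatter) is therefore expected, leaning weaker. Compound 4 is estimated at 7000 nM, within 2500 nM to 20000 nM.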

Compound 4, half-maximal inhibitory concentration: 670 nM
Compound 4: the middle estimate sits 10-fold (1.02 log units) above what was measured; measured number outside the range, below it.
By their numbers in this assay, from the lowest: compound 4; then compounds 1 and 2 (each within the scatter of the next); then compound 3.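

On the carbonyl carbon, the group matters: 4-nitrophenyl in place of methyl gives a 6.7-fold lower number from compound 1 to compound 4 (0.83 log units; beyond the scatter), whereas the earlier replacement of the whole acetoxy group stayed within the scatter. Against the silicon group of compound 2, the ((4-nitrophenyl)carbonyl)oxy compound shows a 9.0-fold lower number from compound 2 to compound 4 (0.95 log units; beyond the scatter), so the lower number is not confined to a single comparison. Nothing at hand accounts for this gain. Still open, going by these compounds, is whether the step needs the nitro group or only the aromatic ring: a plain phenyl or a 4-aminophenyl on the same carbonyl carbon would separate the two.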